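The source may report more compounds than this note shows. Statements on the series, on what has been measured and on what is new or still open speak of the compounds shown alone.

Working notes on the series. The compounds share one core and differ only in the aromatic group attached to it: compound 1 `CCOC(=O)c1cnc(-c2cccs2)nc1NN1C(=O)C=C(C)C1=O`, compound 2 `CCOC(=O)c1cnc(-c2ccc(C(F)(F)F)cc2)nc1NN1C(=O)C=C(C)C1=O`, compound 3 `CCOC(=O)c1cnc(-c2cccc(Br)c2)nc1NN1C(=O)C=C(C)C1=O` and the not yet measured compound 4 `CCOC(=O)c1cnc(-c2cccc([N+](=O)[O-])c2)nc1NN1C(=O)C=C(C)C1=O`. In a functional assay on Jurkat cells for inhibition of nuclear factor NF-kappa-B complex (Homo sapiens) (on this read-out higher numbers stand for weaker inhibition and lower numbers for stronger inhibition), compound 1 gives 20 nM, compound 2 gives 400 nM, and compound 3 gives 700 nM. Compound 3 thus shows the highest of the three numbers, but its distance from compound 2 is small, a 1.8-fold higher number from compound 2 to compound 3 (0.24 log units; within the scatter), while its distance from compound 1 is large, a 35-fold higher number from compound 1 to compound 3 (1.54 log units; beyond the scatter). The other large step in the set is a 20-fold higher number from compound 1 to compound 2 (1.30 log units; beyond the scatter).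

Compound 4 differs from compound 3 by nitro in place of bromo on an aromatic carbon. Among the compounds with values here, no measured step swaps one substituent on the phenyl ring for another while keeping the ring, so the closest comparison is a 1.8-fold higher number from compound 2 to compound 3 (0.24 log units; within the scatter), which stayed within the scatter, whereas the two large steps, a 20-fold higher number from compound 1 to compound 2 (1.30 log units; beyond the scatter) and a 35-fold higher number from compound 1 to compound 3 (1.54 log units; beyond the scatter), both came from replacing thiophen-2-yl with a substituted phenyl. For compound 4, which keeps the phenyl, a step within the scatter in this assay is therefore expected, with no firm direction. The estimate for compound 4 is 600 nM, with a range from 200 nM to 2000 nM, corresponding to an expected step of a 1.2-fold lower number from compound 3 to compound 4 (0.07 log units; within the scatter).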

Compound 4, half-maximal inhibitory concentration: 7000 nM
For compound 4 the middle estimate is 12-fold (1.07 log units) below the measured one, outside the stated range (above it).
By their numbers in this assay, from the lowest: compound 1; then compounds 2 and 3 (each within the scatter of the next); then compound 4.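

Keeping the phenyl ring does not guarantee a small step: in this assay, nitro in place of bromo on this aromatic carbon, meta to a large group, gives a 10-fold higher number from compound 3 to compound 4 (1.00 log units; beyond the scatter), so the substituent alone can move the read-out beyond the scatter. The comparison with the 4-(trifluoromethyl)phenyl analogue points the same way, with an 18-fold higher number from compound 2 to compound 4 (1.24 log units; beyond the scatter), although a 1.8-fold higher number from compound 2 to compound 3 (0.24 log units; within the scatter) had suggested that substituted phenyl groups might behave alike. Replacing thiophen-2-yl with 3-nitrophenyl now gives the widest step in the set, a 350-fold higher number from compound 1 to compound 4 (2.54 log units; beyond the scatter), and nothing available accounts for the difference between bromo and nitro at this position.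

Going by these compounds, with only bromo and nitro represented at this carbon, it remains open whether nitro is an isolated case or one end of a wider trend, which an amine, a methoxy group or a carboxylic acid at the same place would help to test. On these data alone, it also remains open whether a nitro group on another carbon of the phenyl ring would give a similar number to compound 4.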